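Aryl variation on the shared core

The source may hold more compounds than are shown below. What is called first, only, known or untested is meant among the compounds shown, and "the series" means these compounds.

Three measured members of the series carry the same core and differ only in the aryl group on the carbon with a double bond to nitrogen. Compound 1 `O=C(CSc1nnc(-c2ccncc2)o1)N/N=C/c1ccccc1` gives 22100 nM in a functional assay on BGC-823 cells (Homo sapiens) for cytotoxicity, read by MTT assay, with a stated time of 48 h; on this read-out lower numbers stand for stronger inhibition and higher numbers for weaker inhibition. Compound 2 `O=C(CSc1nnc(-c2ccncc2)o1)N/N=C/c1ccc(Cl)cc1` gives 20500 nM in this assay, and compound 3 `O=C(CSc1nnc(-c2ccncc2)o1)N/N=C/c1ccc(Br)cc1` gives 24500 nM. Compound 2 has the lowest of the three numbers, but the gaps are small: a 1.1-fold lower number from compound 1 to compound 2 (0.03 log units; within the scatter), a 1.2-fold higher number from compound 2 to compound 3 (0.08 log units; within the scatter) and a 1.1-fold higher number from compound 1 to compound 3 (0.04 log units; within the scatter), all within the scatter, so no order among the three can be claimed.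

Compound 4 `O=C(CSc1nnc(-c2ccncc2)o1)N/N=C/c1ccccc1[N+](=O)[O-]` is not yet measured. Its change from compound 2 is 2-nitrophenyl in place of 4-chlorophenyl on a carbon with a double bond to nitrogen. On these data alone, the measured steps that bear on it are the aryl substitutions just described, each within the scatter; none of them involves a 2-nitrophenyl group, so that group itself is untested. With chloro, bromo or hydrogen on that ring leaving the number essentially unchanged, no step beyond the scatter is expected here either: a 1.1-fold higher number from compound 2 to compound 4 (0.03 log units; within the scatter). Compound 4 is therefore estimated at 22000 nM, with a range from 10000 nM to 48000 nM.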

Compound 4, half-maximal inhibitory concentration: 41600 nM
Compound 4: middle estimate off by 1.9-fold (0.28 log units), on the low side; the measured number falls inside the stated range.
By their numbers in this assay, from the lowest: compounds 2, 1, 3 and 4 (each within the scatter of the next, the first and the last beyond it).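

In this assay, among the compounds shown here, the aryl group on the carbon with a double bond to nitrogen is not wholly indifferent to change: a 2.0-fold higher number from compound 2 to compound 4 (0.31 log units; beyond the scatter) is the only step so far beyond the scatter, and it is a modest one. The other two steps, a 1.7-fold higher number from compound 3 to compound 4 (0.23 log units; within the scatter) and a 1.9-fold higher number from compound 1 to compound 4 (0.27 log units; within the scatter), remain within the scatter, so 2-nitrophenyl stands apart from 4-chlorophenyl alone and not from 4-bromophenyl or unsubstituted phenyl. No measurement at hand accounts for the step.

On these data alone, with a single nitro compound, it stays open whether the step from 4-chlorophenyl belongs to the nitro group itself or to where it sits on the ring. Also open, as far as these compounds go, is how an amine or a carboxylic acid on this aryl ring would read.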